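Methoxy for tert-Butyl on the Shared Core

This account rests on a few compounds, and the source may have more. Where it says the series, first, only, none or still open, it means among the compounds named here.

Of the compounds shown here, three have so far been measured in an ADME assay on the whole organism with Oryza sativa as the target, tested at 1 uM; on this read-out lower numbers stand for a stronger effect and higher numbers for a weaker effect at the one concentration tested. Compound 1 `Cc1ccccc1NC(=O)N[C@@H](C)c1ccccc1` carries a methyl on an aromatic carbon and gives 99%. Compound 2 `C[C@@H](NC(=O)Nc1ccccc1C(C)(C)C)c1ccccc1` gives 95%, and compound 3 `C[C@H](NC(=O)Nc1ccccc1C(C)(C)C)c1ccccc1` gives 99% in this assay. The two steps that connect them are both small: no change at the digits printed from compound 1 to compound 3 (within the scatter), and a number 4 percentage points higher from compound 2 to compound 3 (within the scatter), the latter step resting on (the fact that compounds 2 and 3 differ only in the configuration as drawn). Compound 3 thus stands level with compound 1, and compound 2 lies within the scatter of both, so the three numbers cannot be told apart.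

The next compound, compound 4 `COc1ccccc1NC(=O)N[C@@H](C)c1ccccc1`, differs from compound 3 by methoxy in place of tert-butyl on an aromatic carbon. Among the measured compounds shown here, no measured step exchanges one group on that aromatic carbon for a group of a different kind in the way this one does; the nearest comparison is the exchange of methyl for tert-butyl, which left the read-out unchanged, and the change of configuration, which also stayed within the scatter. Compound 4 is therefore expected to show a number 2 percentage points lower from compound 3 to compound 4 (within the scatter) in this assay, that is, no change beyond the scatter. The estimate for compound 4 is 97%, within a range from 88% to 100%.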

Compound 4, a percentage reported as activity, at one concentration (the size of the read-out at that concentration, not a potency): 99%
Beside the measured number, compound 4's estimate is 2 percentage points below it; the measured number falls inside the stated range.
By their numbers in this assay, from the lowest: compounds 2, 1, 3 and 4 (each within the scatter of the next).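

Methoxy is the first group on this aromatic carbon to bring an oxygen and a hydrogen-bond acceptor, and the read-out of this assay shows no change at the digits printed from compound 3 to compound 4 (within the scatter) when it replaces tert-butyl. Set against methyl the exchange gives the same picture, with no change at the digits printed from compound 1 to compound 4 (within the scatter) on the shared core, so methyl, tert-butyl and methoxy on this carbon cannot be told apart at the one concentration tested, even though methoxy differs from the other two in kind and not only in the size of a carbon group. Nothing measured here speaks to why the read-out stays level across these groups.

The compounds shown leave open whether any group on this aromatic carbon can move the read-out beyond the scatter at all, and an amine, a carboxylic acid or a longer chain there would test this more sharply than the three groups seen so far. They also leave open whether a change elsewhere on the shared core, such as a chlorine on the other aromatic ring, would do what these exchanges have not.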